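Nitro in place of trifluoromethyl on compound 3

This account rests on a few compounds, and the source may have more. Where it says the series, first, only, none or still open, it means among the compounds named here.

In a functional assay on HeLa cells (Homo sapiens) for inhibition, with a stated time of 72 h (on this read-out lower numbers stand for an effect already at smaller amounts and higher numbers for an effect only at larger amounts of compound), compound 3 (`COc1cc(CNCc2ccncc2)ccc1OCc1ccc(C(F)(F)F)cc1`) gives 2400 nM. Compound 2 (`Clc1ccc(COc2ccc(CNCc3ccncc3)cc2)cc1`) gives 4000 nM, a number within the scatter of that of compound 3. Compound 1 (`COc1cc(CNCc2ccccc2)ccc1OCc1ccc(Cl)nc1`) gives 90000 nM, a higher number and beyond the scatter from compound 3.

Compound 4 (`COc1cc(CNCc2ccncc2)ccc1OCc1ccc([N+](=O)[O-])cc1`) is still unmeasured. It has nitro in place of trifluoromethyl on an aromatic carbon, para to a large group: nitro in place of trifluoromethyl on an aromatic carbon. Going by the values given here, the measured compounds include no pair that differs in one place, so nothing shows directly what this exchange does in this assay. No step beyond the scatter is therefore expected, with a slight lean towards a higher number, and this expectation starts from compound 3 at 2400 nM. The estimated move is a 1.3-fold higher number from compound 3 to compound 4 (0.10 log units; within the scatter). For compound 4 the expected value is 3000 nM, within an estimated range of 1000 nM to 9000 nM.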

Compound 4, half-maximal effective concentration: 440 nM
Compound 4: the middle estimate sits 6.8-fold (0.83 log units) above what was measured; measured number below the stated range.
By their numbers in this assay, from the lowest: compound 4; then compounds 3 and 2 (each within the scatter of the next); then compound 1.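

In this assay, going by these compounds alone, nitro in place of trifluoromethyl on an aromatic carbon, para to a large group, gives a 5.5-fold lower number from compound 3 to compound 4 (0.74 log units; beyond the scatter) and so provides the first step here between two compounds that differ in one place. Within the data shown here, this shows that the number in this assay changes beyond the scatter with the group at this position, which the earlier compounds, differing in more than one place, could not show. Nothing available explains why this exchange produces the step.

The compounds shown leave open how a nitrile, an amine or a carboxylic acid at this position would compare with nitro. They also leave open whether the same exchange would give a similar step on the core of compound 1 or of compound 2.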